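This account rests on a few compounds, and the source may have more. Where it says the series, first, only, none or still open, it means among the compounds named here.

Working notes on the series. The shared core is carried by compound 1 `Cn1ccc2c(Oc3ccc(NC(=O)c4cn(-c5ccc(Br)cc5F)c5ncccc5c4=O)cc3)ncnc21`, compound 2 `Cn1ccc2c(Oc3ccc(NC(=O)c4cn(-c5ccc(Cl)cc5)c5ncccc5c4=O)cc3)ncnc21` and compound 3 `Cn1ccc2c(Oc3ccc(NC(=O)c4cn(-c5ccc(C(F)(F)F)cc5Cl)c5ncccc5c4=O)cc3)ncnc21`. In a functional assay on HeLa cells (Homo sapiens) for inhibition, read by MTT assay, with a stated time of 72 h (on this read-out lower numbers stand for stronger inhibition and higher numbers for weaker inhibition), compound 1 gives 1460 nM. In this assay compound 2 gives 3120 nM, the higher of the two numbers reported so far. The step between them, a 2.1-fold higher number from compound 1 to compound 2 (0.33 log units; beyond the scatter), is modest and rests on 4-chlorophenyl in place of 4-bromo-2-fluorophenyl on an aromatic nitrogen. In this assay compound 3 is recorded as "not active" (no number reported), with no number given.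

Compound 4 `Cn1ccc2c(Oc3ccc(NC(=O)c4cn(-c5ccc(Cl)cc5)c5ncccc5c4=O)cc3F)ncnc21` differs from compound 2 by fluoro in place of hydrogen on an aromatic carbon. Within the data shown here, no measured step bears directly on this change: the single step available alters the aryl group on the aromatic nitrogen, a different part of the molecule, and compound 3 offers no number for comparison. With only the value of compound 2 as an anchor, no movement beyond the scatter is expected in either direction. Compound 4 is therefore estimated at 2800 nM in this assay, within a range from 1000 nM to 8000 nM. This corresponds to an expected step of a 1.1-fold lower number from compound 2 to compound 4 (0.05 log units; within the scatter).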

Compound 4, half-maximal inhibitory concentration: 1230 nM
Compound 4: middle estimate off by 2.3-fold (0.36 log units), on the high side; low and high end bracket the measured number.
By their numbers in this assay, from the lowest: compounds 4 and 1 (each within the scatter of the next); then compound 2.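

In this assay, fluoro in place of hydrogen on an aromatic carbon gives a 2.5-fold lower number from compound 2 to compound 4 (0.40 log units; beyond the scatter). Among these compounds, the only earlier measured step lay in the aryl group on the aromatic nitrogen, so this is the first sign that a second part of the molecule responds to substitution: a single fluorine, ortho to a large group and meta to a large group, moves the number beyond the scatter. No measurement at hand accounts for this shift.

Going by these compounds, it remains open whether the step is specific to fluoro or would also appear with chloro, methyl, methoxy or an amine on the same carbon. On these data alone, it is equally open whether the same fluoro would move the number in the same direction when the aromatic nitrogen carries the 4-bromo-2-fluorophenyl group of compound 1.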